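From tert-butyl to methyl on the aryl of compound 3

The source may hold more compounds than are shown below. What is called first, only, known or untested is meant among the compounds shown, and "the series" means these compounds.

Compound 3 `CC(C)(C)c1ccc(-c2cn(C/C=C3\OC(=O)C(OCc4ccccc4)=C3OCc3ccccc3)nn2)cc1` was tested in a functional assay on MCF7 cells (Homo sapiens) for antiproliferative activity, read by MTT assay, with a stated time of 24 h; on this read-out higher numbers stand for weaker inhibition and lower numbers for stronger inhibition. Compound 3 reaches only the assay limit there, > 100000 nM. Compound 2 `O=C1NC(O)(CCn2cc(C3=CCCCC3)nn2)C(OCc2ccccc2)=C1OCc1ccccc1` likewise reaches only the limit, > 100000 nM. Compound 1 `O=C1O/C(=C\Cn2cc(Cc3ccccc3)nn2)C(OCc2ccccc2)=C1OCc1ccccc1` gives a numerical value of 40000 nM in this assay, and the step of an at least 2.5-fold higher number from compound 1 to compound 3 (0.39 log units; beyond the scatter) ends at the limit of > 100000 nM in this assay, at which 2 of the 3 values shown sit. Compound 4 `Cc1ccc(-c2cn(C/C=C3\OC(=O)C(OCc4ccccc4)=C3OCc3ccccc3)nn2)cc1` differs from compound 3 by methyl in place of tert-butyl on an aromatic carbon. Among the compounds with values here, only the step from compound 1 to compound 3 bears on this change, and only indirectly, since it altered the whole aryl group rather than its substituent alone. Compound 4 is expected to stay weak in this assay, with an estimated 80000 nM (range 30000 nM to 200000 nM). The expected step of an at least 1.2-fold lower number from compound 3 to compound 4 (0.09 log units; that floor lies within the scatter) may not clear the scatter.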

Compound 4, half-maximal inhibitory concentration: > 100000 nM
Compound 4 was reported as a limit; the forecaster's own chance of this, stated with the estimate: 50%; middle value at least 1.2-fold (0.09 log units) from the limit.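

Neither tert-butyl nor methyl on the aryl gives a numerical value in this assay: compound 3 and compound 4 both stand at a limit, so the step between them cannot be read. Benzyl replaced by 4-methylphenyl gives an at least 2.5-fold higher number from compound 1 to compound 4 (0.39 log units; beyond the scatter), so the higher number seen with 4-(tert-butyl)phenyl does not require the tert-butyl group. The series now gathers at one ceiling: the limit of > 100000 nM in this assay, at which 3 of the 4 values shown sit.

From the compounds shown here alone, whether an amine or a carboxylic acid in place of methyl on this aryl would return a numerical value stays open.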